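A few compounds are considered here, and "the series" means these few. Any claim that something is new, unique, unknown or untested is made for them only; others in the source may bear on it.

Measured so far in an ADME assay on HeLa cells (Homo sapiens) for cytotoxicity, read by resazurin assay, with a stated time of 65 h (on this read-out higher numbers stand for an effect only at larger amounts of compound and lower numbers for an effect already at smaller amounts), as limits:

Compound 1 (`CCc1cc(C(=O)OC)c(NC(=O)c2ccc([N+](=O)[O-])o2)s1`): > 20000 nM as a limit
Compound 2 (`COc1cccc(NC(=O)c2ccc([N+](=O)[O-])o2)c1`): > 20000 nM as a limit
Compound 3 (`O=C(Nc1ccc(C(F)(F)F)cc1)c1ccc([N+](=O)[O-])o1`): > 20000 nM as a limit

Compound 3 stands at > 20000 nM as a limit and not as a number. Among the compounds with values here, the series offers only the limit of > 20000 nM in this assay, at which 3 of the 3 values shown sit, and no measured step. Compound 4 (`COC(=O)c1ccc(NC(=O)c2ccc([N+](=O)[O-])o2)cc1`) has methoxycarbonyl in place of trifluoromethyl on an aromatic carbon, para to a large group (methoxycarbonyl in place of trifluoromethyl on an aromatic carbon). In this assay no change beyond the scatter is expected, and another limit is the likeliest report. The expected step is a step that the limit leaves unreadable from compound 3 to compound 4 and remains small. Compound 4 is estimated at 25000 nM with 10000 nM to 50000 nM as the expected range.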

Compound 4, half-maximal effective concentration: > 20000 nM
Compound 4 was reported as a limit; the forecaster's own chance of this, stated with the estimate: 75%; the middle value lies beyond the limit too.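

Compound 4, like compound 3, is reported only as a limit, so no step can be read between them: the limit of > 20000 nM in this assay, at which 4 of the 4 values shown sit.

The compounds shown leave open which change to the shared core, if any, would give a readable value in this assay.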